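A Third Fluorine on the Aryl Ether

This account rests on a few compounds, and the source may have more. Where it says the series, first, only, none or still open, it means among the compounds named here.

Compound 2 `Cc1cc(COc2ccc(F)cc2F)nc(-c2ccccn2)n1` gives 398 nM in a functional assay on cells for antagonist activity at Free fatty acid receptor 1 (Homo sapiens), read by TR-FRET and inositol phosphate accumulation, with a stated time of 2 h (on this read-out higher numbers stand for weaker inhibition and lower numbers for stronger inhibition), and stands level with compound 1 `Cc1cc(COc2ccccc2F)nc(-c2ccccn2)n1`, which gives 398 nM. Going by the values given here, the one step that bears on the question, no change at the digits printed from compound 1 to compound 2 (within the scatter), brought in a single fluoro and left the number unchanged within the scatter. Compound 3 `Cc1cc(COc2cc(F)c(F)cc2F)nc(-c2ccccn2)n1` differs from compound 2 by fluoro in place of hydrogen on an aromatic carbon. On that precedent alone, the expected step in this assay is a 1.0-fold higher number from compound 2 to compound 3 (0.00 log units; within the scatter), nothing beyond the scatter. Compound 3 is therefore estimated at 400 nM, within a range of 180 nM to 900 nM.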

Compound 3, half-maximal inhibitory concentration in the Free fatty acid receptor 1 assay: 398 nM
Beside the measured number, compound 3's estimate is 1.0-fold (0.00 log units) above it; low and high end bracket the measured number.
By their numbers in the Free fatty acid receptor 1 assay, from the lowest: compounds 1, 2 and 3 (each within the scatter of the next).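

In the Free fatty acid receptor 1 assay the new fluoro, ortho to a fluoro group and para to a fluoro group, gives no change at the digits printed from compound 2 to compound 3 (within the scatter) and compound 3 gives 398 nM here, so a second such step on this ring also leaves the number level, now with three fluoro groups in place. In a physicochemical assay for lipophilicity, at pH 7.4 (a lower number here means a more polar compound, a higher number a more lipophilic compound), the same change gives a number 0.10 log units higher from compound 2 to compound 3 (within the scatter) and this adds the physicochemical assay for this step, with compound 2 at 3.1 and compound 3 at 3.2 on that scale. Nothing at hand gives a reason for either result. As far as these compounds go, whether this position accepts anything other than fluoro stays open. An amine or a carboxylic acid here could give a different result, and the compounds shown cannot tell.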